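The source may hold more compounds than are shown below. What is called first, only, known or untested is meant among the compounds shown, and "the series" means these compounds.

Working notes on the series. Among the compounds with values here, in a functional assay on C6 cells (Rattus norvegicus) for cytotoxicity, read by MTT assay, with a stated time of 24 h, tested at 100 ug/mL (on this read-out higher numbers stand for a weaker effect at the one concentration tested and lower numbers for a stronger effect), compound 3 `O=C(CSc1nnnn1-c1ccccc1)N/N=c1/scc(-c2ccc(Cl)cc2)n1-c1ccccc1` gives 54.3%, the highest of the three numbers so far, with both other compounds beyond the scatter below it. Compound 1 `O=C(CSc1nnnn1-c1ccccc1)N/N=c1/scc(-c2ccccc2)n1-c1ccccc1` gives 35.8%; compound 2 `Cc1nnc(SCC(=O)N/N=c2/scc(-c3ccc(F)cc3)n2-c2ccccc2)s1` gives 34.9%. Within the data shown here, compound 2 differs from compound 3 in more than one place, so the two values show only that a fluoro-bearing analogue of another kind lands near compound 1.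

Compound 4 `O=C(CSc1nnnn1-c1ccccc1)N/N=c1/scc(-c2ccc(F)cc2)n1-c1ccccc1` differs from compound 3 by fluoro in place of chloro on an aromatic carbon. Among the measured compounds shown here, the one measured step at the same aromatic carbon is a number 18.5 percentage points higher from compound 1 to compound 3 (beyond the scatter), chloro in place of hydrogen, a modest rise beyond the scatter. For the measured compounds named here, no measured step exchanges chloro for fluoro on the shared core of compound 3, and compound 2, the only fluoro-bearing compound, is not a single-change neighbour of either compound 3 or compound 4. In this assay a downward step from compound 3 to compound 4 is therefore expected, smaller than the step from compound 1 to compound 3, since compound 1 at 35.8% marks the unsubstituted parent. The expected value for compound 4 is 43%, with a range of 31% to 57%. The expected step is a number 11.3 percentage points lower from compound 3 to compound 4 (beyond the scatter).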

Compound 4, a percentage reported as activity, at one concentration (the size of the read-out at that concentration, not a potency): 35.8%
Compound 4: middle estimate off by 7.2 percentage points, on the high side, within the range that was stated.
By their numbers in this assay, from the lowest: compounds 2, 1 and 4 (each within the scatter of the next); then compound 3.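

Fluoro and chloro do not behave alike at this position, para to a large group: in this assay, the exchange gives a number 18.5 percentage points lower from compound 3 to compound 4 (beyond the scatter), while fluoro in place of hydrogen gives no change at the digits printed from compound 1 to compound 4 (within the scatter), so the rise seen with chloro, a number 18.5 percentage points higher from compound 1 to compound 3 (beyond the scatter), does not appear with fluoro. Within the data shown here, compound 4 also provides the first single-change reading at the sulfur, where 1-phenyl-1H-tetrazol-5-yl in place of 5-methyl-1,3,4-thiadiazol-2-yl gives a number 0.9 percentage points higher from compound 2 to compound 4 (within the scatter), so with 4-fluorophenyl on the shared core this exchange does not separate the two compounds. No available evidence accounts for the separation of chloro from fluoro and hydrogen at this aromatic carbon.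

Still open, on these data alone, is whether a bromo, a methoxy or an amine on the same aromatic carbon would give a number close to that of compound 3 or close to that of compound 1. The compounds shown also leave open whether the step from hydrogen to chloro would recur with 5-methyl-1,3,4-thiadiazol-2-yl on the sulfur, since the only compound carrying that group here bears fluoro.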